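The source may report more compounds than this note shows. Statements on the series, on what has been measured and on what is new or still open speak of the compounds shown alone.

Compound 1 `Nc1cc(N)c2nc(-c3ccccc3)c(Oc3ccc(Cl)c(Cl)c3)nc2c1` carries the larger of the two numbers shown: in a functional assay on MDA-MB-231 cells (Homo sapiens) for inhibition, read by sulforhodamine B assay, with a stated time of 48 h (on this read-out higher numbers stand for weaker inhibition of growth and lower numbers for stronger inhibition of growth), compound 1 gives 26300 nM. Compound 2 `COc1ccc(CNc2nc3cc(N)cc(N)c3nc2-c2ccccc2)cc1` lies close by, since in this assay compound 2 gives 13800 nM, a gap within the scatter, so the two cannot be ranked. Compound 3 `Nc1cc(N)c2nc(-c3ccccc3)c(Oc3ccc(F)cc3)nc2c1` differs from compound 1 by 4-fluorophenyl in place of 3,4-dichlorophenyl on an oxygen on an aromatic ring. Among the compounds with values here, no measured pair shows this change, so in this assay only a step within the scatter is expected, with no firm direction. The expected step is a 1.1-fold higher number from compound 1 to compound 3 (0.06 log units; within the scatter). Compound 3 is estimated at 30000 nM, between 10000 nM and 90000 nM.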

Compound 3, concentration for total growth inhibition: 28800 nM
Beside the measured number, compound 3's estimate is 1.0-fold (0.02 log units) above it; the range from low to high includes it.
By their numbers in this assay, from the lowest: compounds 2, 1 and 3 (each within the scatter of the next, the first and the last beyond it).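

With 4-fluorophenyl in place of 3,4-dichlorophenyl on an oxygen on an aromatic ring, this assay shows a 1.1-fold higher number from compound 1 to compound 3 (0.04 log units; within the scatter). Within the data shown here, this is the first pair here that differs in one place, and it shows that this change leaves the number within the scatter, so neither compound can be ranked above the other. No measurement shown here bears on this result. Still open, from the compounds shown here alone, is whether a carboxylic acid or a primary amine on this phenyl ring would move the number beyond the scatter. Replacing the oxygen link with a longer chain remains equally untested among these compounds.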